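A few compounds are considered here, and "the series" means these few. Any claim that something is new, unique, unknown or untested is made for them only; others in the source may bear on it.

Compound 1, `Cc1ccc(OCC(=O)N(Cc2cccs2)c2ccn(C)n2)cc1`: 855 nM
Compound 2, `Cc1ccc(OCC(=O)N(Cc2cccs2)c2ncco2)cc1`: 0.3 nM
Compound 3, `Cc1ccc(OCC(=O)N(Cc2cccs2)C(C)C)cc1`: 70 nM

These three compounds were tested in an assay on HEK293 cells for agonist activity at transient receptor potential cation channel subfamily M member 8 (Homo sapiens), read by fluorescence and calcium flux, with a stated time of 15 min; a higher number here means that more compound is needed for the effect, a lower number that less compound is needed. Compound 3 stands second highest of the three numbers: its nearest neighbour is compound 1, reached by a 12-fold lower number from compound 1 to compound 3 (1.09 log units; beyond the scatter), while compound 2 lies furthest away, shown by a 230-fold higher number from compound 2 to compound 3 (2.37 log units; beyond the scatter).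

Compound 4, `Cc1ccc(OCC(=O)N(Cc2cccs2)c2cnn(C)c2)cc1`, has not yet been measured. It differs from compound 3 in one place: 1-methyl-1H-pyrazol-4-yl in place of isopropyl on an amide-type nitrogen.

Among the compounds with values here, two measured steps bear on this change, since both swap the isopropyl of compound 3 for a five-membered aromatic ring on the same amide-type nitrogen. The step of a 12-fold lower number from compound 1 to compound 3 (1.09 log units; beyond the scatter) shows such a ring giving a higher number than isopropyl, whereas a 230-fold higher number from compound 2 to compound 3 (2.37 log units; beyond the scatter) shows another such ring giving a far lower number. A large step in either direction is therefore plausible, and the direction is uncertain. Since compound 1 also carries a methylated pyrazole, the estimate for compound 4 leans toward a higher number than compound 3, expected as a 4.3-fold higher number from compound 3 to compound 4 (0.63 log units; beyond the scatter). The estimated value for compound 4 is 300 nM, with an expected range from 30 nM to 3000 nM.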

Compound 4, half-maximal effective concentration: 63000 nM
The estimate for compound 4 lay 210-fold (2.32 log units) below the measured number; the measured number lies above the stated range.
By their numbers in this assay, from the lowest: compound 2; then compound 3; then compound 1; then compound 4.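

In this assay, putting 1-methyl-1H-pyrazol-4-yl on the amide-type nitrogen in place of isopropyl raises the number sharply (a 900-fold higher number from compound 3 to compound 4 (2.95 log units; beyond the scatter)), and the gap to the 1,3-oxazol-2-yl group is far wider (a 210000-fold higher number from compound 2 to compound 4 (5.32 log units; beyond the scatter)). The two methylated pyrazoles, which hold the same atoms and differ in how the ring is attached, also lie well apart (a 74-fold higher number from compound 1 to compound 4 (1.87 log units; beyond the scatter)), so the presence of a methylated pyrazole at this place does not settle the number and the way the ring is attached matters among these compounds. No measurement here explains these differences.

The compounds shown leave open whether the very low number of compound 2 belongs to 1,3-oxazol-2-yl alone. A 1,3-thiazol-2-yl or phenyl group on the same nitrogen would help show how far that low number extends to other rings.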